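From 4-chlorophenyl to phenyl in a cytotoxicity test

The source may hold more compounds than are shown below. What is called first, only, known or untested is meant among the compounds shown, and "the series" means these compounds.

Compound 1 `FC(F)(F)c1cccc(NC(=S)Nc2ccc(Cl)cc2)c1` gives 10000 nM
Compound 2 `CCCCc1ccc(NC(=S)Nc2cccc(C(F)(F)F)c2)c(C)c1` gives 9000 nM

In an ADME assay on BHK cells (Mesocricetus auratus) for cytotoxicity, read by MTT assay, with a stated time of 96 h (on this read-out lower numbers stand for higher toxicity in this test and higher numbers for lower toxicity in this test), compound 1 and compound 2 stand within the usual scatter of each other, so neither can be placed ahead of the other. Compound 3 `FC(F)(F)c1cccc(NC(=S)Nc2ccccc2)c1` differs from compound 1 by hydrogen in place of chloro on an aromatic carbon, para to a large group (hydrogen in place of chloro on an aromatic carbon). Within the data shown here, no measured pair shows this change, so no step beyond the scatter is expected in this assay on present evidence. On these data alone, the estimated change is a 1.2-fold higher number from compound 1 to compound 3 (0.08 log units; within the scatter) and its direction remains open. Compound 3 is estimated at 12000 nM within an expected range of 5000 nM to 30000 nM for now.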

Compound 3, half-maximal cytotoxic concentration: 41000 nM
Beside the measured number, compound 3's estimate is 3.4-fold (0.53 log units) below it; measured number outside the range, above it.
By their numbers in this assay, from the lowest: compounds 2 and 1 (each within the scatter of the next); then compound 3.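

In this assay, among these compounds, hydrogen in place of chloro, para to a large group, gives a 4.1-fold higher number from compound 1 to compound 3 (0.61 log units; beyond the scatter), the first step at this position that can be read. On this aromatic carbon, then, chloro and hydrogen can be told apart, with hydrogen going with the lower toxicity in this test. Nothing at hand accounts for the step.

The compounds shown leave open whether fluoro, methoxy or an amine at this same place would stand with chloro or with hydrogen. They also leave open whether the step would recur on another core.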